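The source may hold more compounds than are shown below. What is called first, only, known or untested is meant among the compounds shown, and "the series" means these compounds.

For the measured compounds named here, compound 2 `CC1=C(C(=O)OCC2CC2)C(c2ccco2)NC(=O)N1` has the higher of the two numbers measured so far: in an assay on membranes from CHO cells for displacement of a labelled ligand from adenosine receptor A1 (Homo sapiens), read by scintillation counting, with a stated time of 60 min, tested at 1 uM (a lower number here means less inhibition, a higher number more inhibition at the concentration tested (going by the name of the read-out)), compound 2 gives 29%, while compound 1 `CCSC(=O)C1=C(C)NC(=O)NC1c1ccco1` gives 6%. Going by the values given here, the single measured step, a number 23 percentage points higher from compound 1 to compound 2 (beyond the scatter), came from swapping the ethylsulfanyl group on the carbonyl carbon for a cyclopropylmethoxy group, a change that touched both the linking atom and the ring.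

Compound 3 `CC1=C(C(=O)OCC2CCC2)C(c2ccco2)NC(=O)N1` keeps the ester and differs from compound 2 only by cyclobutyl in place of cyclopropyl on a saturated chain carbon bound to an oxygen next to a carbonyl group. Among the compounds with values here, no measured step bears directly on growing a small carbon ring by one member; the step from compound 1 to compound 2 involved a larger exchange, so it gives only a loose hint that the ring end of this chain matters somewhat. A step of at most modest size is therefore expected. Compound 3 is estimated to give about 32%, with a range from 12% to 52%. The expected step of a number 3 percentage points higher from compound 2 to compound 3 (within the scatter) is thus estimated to stay near or within the scatter.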

Compound 3, a percentage reported as inhibition, at one concentration (the size of the read-out at that concentration, not a potency): 42%
Estimate against measurement, compound 3: 10 percentage points below; measured number inside the range.
By their numbers in this assay, from the lowest: compound 1; then compound 2; then compound 3.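

In this assay, the earlier step changed the linking atom and the ring together, whereas this one alters only the ring at the end of the chain: cyclobutyl in place of cyclopropyl gives a number 13 percentage points higher from compound 2 to compound 3 (beyond the scatter), so the ring alone can shift the read-out beyond the scatter. For the compounds shown here, the full exchange of cyclobutylmethoxy in place of ethylsulfanyl on the carbonyl carbon gives a number 36 percentage points higher from compound 1 to compound 3 (beyond the scatter), the only step of large size so far. Nothing available explains why the larger ring goes with more inhibition.

On these data alone, whether the rise continues with cyclopentyl or cyclohexyl in the same place, or whether an open chain such as isobutyl does as well, remains open. As far as these compounds go, these percentages at one concentration are also not potencies, so the true affinity of the compounds remains open too.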